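Swapping the quinoline on a weakly cytotoxic diterpenoid

The compounds below may be only part of what the source reports. "The series", "measured", "known", "first", "only" and "open" are said of these compounds alone.

Compound 1 `C=C1CC[C@@H]2[C@](C)(CO)[C@H](O)CC[C@@]2(C)[C@@H]1C/C=C1/C(=O)OC[C@@H]1Oc1cccc2ccc(C)nc12` was tested in an ADME assay on SNB-19 cells (Homo sapiens) for cytotoxicity, read by MTT assay, with a stated time of 24 h; a higher number here means that more compound is tolerated, a lower number that less compound is tolerated. In that assay compound 1 gives only a limit, > 100000 nM. Compound 2 `C=C1CC[C@@H]2[C@](C)(COC(C)=O)[C@H](O)CC[C@@]2(C)[C@@H]1C/C=C1/C(=O)OC[C@H]1Oc1cccc2ccc(C)nc12` likewise gives only a limit in this assay, > 100000 nM. Compound 3 `C=C1CC[C@@H]2[C@](C)(COC(C)=O)[C@H](O)CC[C@@]2(C)[C@@H]1C/C=C1/C(=O)OC[C@@H]1Oc1cccc2ccc(C)nc12` gives 65900 nM in this assay. The steps of an at least 1.5-fold lower number from compound 1 to compound 3 (0.18 log units; that floor lies within the scatter) and an at least 1.5-fold lower number from compound 2 to compound 3 (0.18 log units; that floor lies within the scatter) can only be traced to a floor that lies within the scatter, because the limit of > 100000 nM in this assay, at which 2 of the 3 values shown sit, caps what either step can show. Compound 4 `C=C1CC[C@@H]2[C@](C)(CO)[C@H](O)CC[C@@]2(C)[C@@H]1C/C=C1/C(=O)OC[C@@H]1Oc1ccnc2ccccc12` differs from compound 1 by quinolin-4-yl in place of 2-methylquinolin-8-yl on an oxygen on a saturated carbon. Going by the values given here, no measured step touches this part of the core, so the measured steps give no direction for it. For compound 4 a number near that of compound 1 is expected, 100000 nM (between 40000 nM and 250000 nM), meaning an expected step of a number no higher from compound 1 to compound 4 (the limit leaves the size open).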

Compound 4, half-maximal cytotoxic concentration: 61200 nM
Compound 4: middle estimate off by 1.6-fold (0.21 log units), on the high side; the measured number falls inside the stated range.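

Quinolin-4-yl in place of 2-methylquinolin-8-yl on an oxygen on a saturated carbon gives the first reading at this position: this assay shows an at least 1.6-fold lower number from compound 1 to compound 4 (0.21 log units; that floor lies within the scatter). Compound 4 thus gives a measured number, but the true size of the step stays unknown because the read-out is capped: the limit of > 100000 nM in this assay, at which 2 of the 4 values shown sit.

From the compounds shown here alone, this swap removes the methyl group and moves the point of attachment together, so their separate contributions remain unknown. Also open, going by these compounds, is how a phenyl group or a longer alkyl chain would read in this place.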